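The source may report more compounds than this note shows. Statements on the series, on what has been measured and on what is new or still open speak of the compounds shown alone.

Three compounds carry the shared core of compound 1 `CC(C)Nc1ccc(-c2ccn3c(CC4CC4)nnc3c2Cl)cc1F`, which in a functional assay on cells for positive allosteric modulation of metabotropic glutamate receptor 2 (Homo sapiens), read by scintillation counting and GTPgammaS binding, with a stated time of 30 min (on this read-out lower numbers stand for an effect already at smaller amounts and higher numbers for an effect only at larger amounts of compound), gives 224 nM. Compound 2 `Clc1cc(-c2ccn3c(CC4CC4)nnc3c2Cl)ccc1OC1CCOCC1` gives 224 nM in this assay, and compound 3 `FC(F)(F)c1c(-c2ccc(OC3CCOCC3)c(Cl)c2)ccn2c(CC3CC3)nnc12` gives 38 nM. Going by the values given here, the one single-point step recorded, a 5.9-fold lower number from compound 2 to compound 3 (0.77 log units; beyond the scatter), is the trifluoromethyl in place of chloro on an aromatic carbon. Compound 3 thereby stands at the lowest of the three numbers, with both compound 1 and compound 2 beyond the scatter above it.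

Compound 4 `FC(F)(F)c1c(-c2ccc(CNC3CCOCC3)c(Cl)c2)ccn2c(CC3CC3)nnc12` differs from compound 3 in one place: ((oxan-4-yl)amino)methyl in place of (oxan-4-yl)oxy on an aromatic carbon. Among the compounds with values here, no measured step bears directly on this change; the values of compound 1 and compound 2 show that two different substituents at this position can give the same number, but those two compounds also differ elsewhere. Within the data shown here, with no precedent for the change, the expected step of a 2.4-fold higher number from compound 3 to compound 4 (0.37 log units; beyond the scatter) for compound 4 is a small one, close to the scatter, in the direction of a somewhat higher number. Compound 4 is therefore estimated at 90 nM, within a range from 25 nM to 350 nM.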

Compound 4, half-maximal effective concentration: 631 nM
Compound 4: middle estimate off by 7.0-fold (0.85 log units), on the low side, and the stated range ends below it.
By their numbers in this assay, from the lowest: compound 3; then compounds 1 and 2 (each within the scatter of the next); then compound 4.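

The position on the aromatic carbon, ortho to a chloro group, proves sensitive to this exchange: in this assay, ((oxan-4-yl)amino)methyl in place of (oxan-4-yl)oxy gives a 17-fold higher number from compound 3 to compound 4 (1.22 log units; beyond the scatter), the first single-point step shown at this position. The entering group keeps the six-membered non-aromatic ring and its hydrogen-bond acceptor count, yet it brings a hydrogen-bond donor and changes how that ring is linked to the aromatic carbon, so retaining the ring does not preserve the number. Nothing measured on these compounds explains the size of this step.

The compounds shown leave open whether the donor or the changed link accounts for the step, a question that a methylene-linked ether or a tertiary amine carrying a methyl group on the nitrogen could address. They also leave open whether the step would be the same with chloro in place of trifluoromethyl on the shared core.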